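This account rests on a few compounds, and the source may have more. Where it says the series, first, only, none or still open, it means among the compounds named here.

Within the data shown here, in a functional assay on HepG2 cells (Homo sapiens) for inhibition, read by MTT assay, with a stated time of 72 h (a lower number here means a stronger inhibitor, a higher number a weaker inhibitor), only two compounds built on the same core have been tested so far. Compound 1 `C#CCSc1nc(NCCC(C)C)c2ccncc2n1` reads > 80000 nM, which is a limit of the assay and not a number. Among the measured compounds shown here, compound 2 `C#CCSc1nc(Nc2ccc(F)cc2)c2ccncc2n1` gives 10800 nM, the only actual number available. For the measured compounds named here, the single measured step is an at least 7.4-fold lower number from compound 1 to compound 2 (0.86 log units; beyond the scatter). Compound 3 `C#CCSc1nc(Nc2ccc([N+](=O)[O-])cc2)c2ccncc2n1` keeps everything in compound 2 except one group: nitro in place of fluoro on an aromatic carbon. This is nitro in place of fluoro on an aromatic carbon, para to a large group. The measured step changed a different place in the molecule, so it gives no size for this change. Going by the values given here, with no measured step at this place, the expectation stays close to compound 2 at 10800 nM, with no shift beyond the scatter. The expected step is a 1.2-fold lower number from compound 2 to compound 3 (0.08 log units; within the scatter). Compound 3 is estimated at 9000 nM, with an expected range from 3000 nM to 28000 nM.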

Compound 3, half-maximal inhibitory concentration: > 80000 nM
Compound 3 gave a limit, no number; the forecaster's own chance of this, stated with the estimate: 8%; middle value at least 8.8-fold (0.94 log units) away from the limit.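

This position on the aromatic ring, para to a large group, is not a neutral place to make a change: in this assay, nitro in place of fluoro gives an at least 7.4-fold higher number from compound 2 to compound 3 (0.86 log units; beyond the scatter). An aromatic ring on the nitrogen is therefore not enough on its own for a measurable reading, since compound 3 keeps that ring and still gives no number. The reading for compound 3 is a limit and not a number, so the step has a minimum size but no known full size: the limit of > 80000 nM in this assay, at which 2 of the 3 values shown sit.

The compounds shown leave open whether fluoro itself is needed at this position or whether other groups would also give a measurable reading. A chlorine, a methyl, a methoxy or an amine at the same place, or a plain hydrogen, would help to settle this.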